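The compounds below may be only part of what the source reports. "The series", "measured", "known", "first", "only" and "open" are said of these compounds alone.

Measured so far in a functional assay on HeLa cells (Homo sapiens) for inhibition, read by MTT assay, with a stated time of 72 h; on this read-out higher numbers stand for weaker inhibition and lower numbers for stronger inhibition:
Compound 1, `CCc1cc(CC)c(C(=O)/C=C/C(=O)O)c(CC)c1`: 6530 nM
Compound 2, `CC(C)(C)c1ccc(C(=O)/C=C/C(=O)O)cc1`: 5100 nM

Both compounds share a core in which an aromatic ring carries a carbonyl linked to an unsaturated carboxylic acid, and they differ only in what sits on that ring. Compound 1 and compound 2 give numbers that sit within the usual scatter of each other, so compound 2 cannot be set apart from compound 1 on the two values shown.

Compound 3, `O=C(O)/C=C/C(=O)c1ccc(Cl)cc1`, is the next step. The change from compound 2 is chloro in place of tert-butyl on an aromatic carbon. Within the data shown here, no measured pair shows what this particular exchange does, so the size of the step must be guessed. A small move toward weaker inhibition, possibly still within the scatter, seems the likeliest outcome. Compound 3 is therefore expected at 8000 nM, within a range of 2500 nM to 25000 nM, the estimated step being a 1.6-fold higher number from compound 2 to compound 3 (0.20 log units; within the scatter).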

Compound 3, half-maximal inhibitory concentration: 25400 nM
Beside the measured number, compound 3's estimate is 3.2-fold (0.50 log units) below it, outside the stated range (above it).
By their numbers in this assay, from the lowest: compounds 2 and 1 (each within the scatter of the next); then compound 3.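

In this assay, the aromatic carbon that carries tert-butyl in compound 2 proves sensitive to what sits on it: chloro in place of tert-butyl gives a 5.0-fold higher number from compound 2 to compound 3 (0.70 log units; beyond the scatter), a move toward weaker inhibition. The earlier compounds shown here could not show this, as they differ in more than one place and so offer no single exchange to read. Nothing shown here explains why this exchange weakens inhibition.

Among these compounds, with only this one exchange, it remains open whether the outcome follows from losing tert-butyl or from introducing chloro. As far as these compounds go, it is also open how a methyl group, an amine or a longer chain on this same aromatic carbon would read, and whether any of them would match compound 2 or fall nearer compound 3.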